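The source may hold more compounds than are shown below. What is called first, only, known or untested is meant among the compounds shown, and "the series" means these compounds.

In a functional assay on HepG2 cells (Homo sapiens) for antiproliferative activity, read by sulforhodamine B assay, with a stated time of 48 h (on this read-out lower numbers stand for stronger inhibition and higher numbers for weaker inhibition), compound 3 `COc1cc(OC)c(/C=C/C(=O)C(=Cc2ccc(O)c(OC)c2)C(=O)/C=C/c2c(OC)cc(OC)cc2OC)c(OC)c1` gives 670 nM, within the scatter of compound 1 `COc1cccc(/C=C/C(=O)C(=Cc2ccc(F)cc2)C(=O)/C=C/c2cccc(OC)c2OC)c1OC` at 580 nM, while compound 2 `COc1cccc(/C=C/C(=O)C(=Cc2ccc(O)c(F)c2)C(=O)/C=C/c2cccc(OC)c2OC)c1OC` at 220 nM lies beyond the scatter below both. Compound 4 `COc1cc(OC)c(/C=C/C(=O)C(=Cc2cc(Br)c(O)c(OC)c2)C(=O)/C=C/c2c(OC)cc(OC)cc2OC)c(OC)c1` differs from compound 3 in one place: bromo in place of hydrogen on an aromatic carbon, turning 4-hydroxy-3-methoxyphenyl into 3-bromo-4-hydroxy-5-methoxyphenyl. Among the compounds with values here, no measured compound carries a bromo group. The closest measured step is a 2.6-fold lower number from compound 1 to compound 2 (0.42 log units; beyond the scatter), a modest one, where 3-fluoro-4-hydroxyphenyl replaces 4-fluorophenyl, and compound 1 and compound 2 also differ from compound 3 elsewhere. A modest lowering in this assay is therefore expected, tentatively: a 1.8-fold lower number from compound 3 to compound 4 (0.25 log units; within the scatter). The estimate for compound 4 is 380 nM, with an expected range of 140 nM to 900 nM.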

Compound 4, half-maximal inhibitory concentration: 660 nM
For compound 4 the middle estimate is 1.7-fold (0.24 log units) below the measured one; low and high end bracket the measured number.
By their numbers in this assay, from the lowest: compound 2; then compounds 1, 4 and 3 (each within the scatter of the next).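

In this assay bromo in place of hydrogen on the aromatic carbon ortho to a hydroxy group and meta to a methoxy group gives a 1.0-fold lower number from compound 3 to compound 4 (0.01 log units; within the scatter) and so leaves the number within the scatter. The earlier compounds shown here carried no bromo group, and the step of a 2.6-fold lower number from compound 1 to compound 2 (0.42 log units; beyond the scatter) proves no guide to this change. No available data bear on why the number holds here.

Open, from the compounds shown here alone, is whether another group on this carbon, such as an amine or a carboxylic acid, would move the number. Also open, going by these compounds, is whether bromo gives the same result on the core of compound 1.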